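Iodo in place of thiophen-2-yl on compound 2

The source may report more compounds than this note shows. Statements on the series, on what has been measured and on what is new or still open speak of the compounds shown alone.

Compound 1 `CSc1ncnc2c1c(-c1cccs1)cn2[C@@H]1O[C@H](CO)[C@@H](O)[C@H]1O`: > 100000 nM
Compound 2 `Cc1ncnc2c1c(-c1cccs1)cn2[C@@H]1O[C@H](CO)[C@@H](O)[C@H]1O`: > 100000 nM

In an ADME assay on MRC5 cells (Homo sapiens), read by MTT assay, with a stated time of 72 h (on this read-out higher numbers stand for weaker inhibition and lower numbers for stronger inhibition), compound 2 gives > 100000 nM, which is a limit. Compound 1 gives > 100000 nM, also a limit. Both therefore sit at the limit of > 100000 nM in this assay, at which 2 of the 2 values shown sit, and compound 2 has no number to start from. Compound 3 `Cc1ncnc2c1c(I)cn2[C@@H]1O[C@H](CO)[C@@H](O)[C@H]1O` carries iodo in place of thiophen-2-yl on an aromatic carbon. Within the data shown here, the only measured step, a step that the two limits leave unreadable from compound 1 to compound 2, concerns a different group and offers no size to carry over. Going by these compounds, a step toward stronger inhibition in this assay is the only one that could be read, and its size remains open. The expected change is an at least 2.5-fold lower number from compound 2 to compound 3 (0.39 log units; beyond the scatter). For compound 3 the estimate is 40000 nM, with an expected range of 5000 nM to 100000 nM.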

Compound 3, half-maximal inhibitory concentration: 13300 nM
For compound 3 the middle estimate is 3.0-fold (0.48 log units) above the measured one, within the range that was stated.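

In this assay, among these compounds, compound 3 gives the first readable number, so this aromatic carbon can shift the read-out, whereas the step from methylsulfanyl to methyl cannot be read between its two limits. Iodo in place of thiophen-2-yl gives an at least 7.5-fold lower number from compound 2 to compound 3 (0.87 log units; beyond the scatter). The size is only a bound because compound 2 sits at a limit: the limit of > 100000 nM in this assay, at which 2 of the 3 values shown sit.

Going by these compounds, whether the stronger inhibition comes from iodo itself or from the loss of thiophen-2-yl remains open. Also open, on these data alone, is how an amine or a longer chain would read at this carbon.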